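Lengthening a para group in a kinase inhibitor series

A few compounds are considered here, and "the series" means these few. Any claim that something is new, unique, unknown or untested is made for them only; others in the source may bear on it.

Compound 1 `Cc1ccc(C(=O)Nc2cccc(NC(=O)COc3ccc4c(=O)ccoc4c3)c2)cc1`: 22 nM in an assay on isolated protein for inhibition of Rho-associated protein kinase 2 (Homo sapiens), read by scintillation counting, radiometric assay and 33P incorporation, with a stated time of 40 min, in the presence of a further agent that is not named here; a lower number here means a stronger inhibitor, a higher number a weaker inhibitor
Compound 2 `CCc1ccc(C(=O)Nc2cccc(NC(=O)COc3ccc4c(=O)ccoc4c3)c2)cc1`: 24 nM in this assay
Compound 3 `COc1ccc(C(=O)Nc2cccc(NC(=O)COc3ccc4c(=O)ccoc4c3)c2)cc1`: 7 nM in this assay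

Compound 1 and compound 2 differ by methyl in place of hydrogen on a saturated chain carbon bound to an aromatic carbon; that change gave a 1.1-fold higher number from compound 1 to compound 2 (0.04 log units; within the scatter). Compound 3 differs from compound 1 by methoxy in place of methyl on an aromatic carbon, which gave a 3.1-fold lower number from compound 1 to compound 3 (0.50 log units; beyond the scatter) and a 3.4-fold lower number from compound 2 to compound 3 (0.54 log units; beyond the scatter). Compound 4 `CCOc1ccc(C(=O)Nc2cccc(NC(=O)COc3ccc4c(=O)ccoc4c3)c2)cc1` has not yet been measured in this assay. It differs from compound 3 by methyl in place of hydrogen on a saturated chain carbon bound to an oxygen on an aromatic ring. This is the same kind of change as from compound 1 to compound 2, but around the place it differs: there the saturated chain carbon was bound to an aromatic carbon, here it is bound to an oxygen on an aromatic ring. Because the earlier step was a 1.1-fold higher number from compound 1 to compound 2 (0.04 log units; within the scatter), the step from compound 3 to compound 4 is expected to be a 1.1-fold higher number from compound 3 to compound 4 (0.06 log units; within the scatter). Compound 4 is therefore estimated at 8 nM, between 3 nM and 20 nM.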

Compound 4, half-maximal inhibitory concentration: 9 nM
Compound 4: middle estimate off by 1.1-fold (0.05 log units), on the low side, and the stated range covers the measured number.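

Methoxy to ethoxy gave a 1.3-fold higher number from compound 3 to compound 4 (0.11 log units; within the scatter), and adding this methyl changed little on either core in this assay: the same change on two cores in this assay, a 1.1-fold higher number (0.04 log units; within the scatter) from compound 1 to compound 2 and a 1.3-fold higher number (0.11 log units; within the scatter) from compound 3 to compound 4, 1.2-fold (0.07 log units) apart, within the scatter of two such steps The oxygen-bearing groups still stood apart from the plain chains, with ethoxy in place of ethyl giving a 2.7-fold lower number from compound 2 to compound 4 (0.43 log units; beyond the scatter) and ethoxy in place of methyl giving a 2.4-fold lower number from compound 1 to compound 4 (0.39 log units; beyond the scatter). These two matched pairs, both from one assay, suggest that this small addition carries across the two cores shown, but they do not show that it would do so on other cores or explain why.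

Going by these compounds, it remains open whether a longer chain such as propoxy would also leave the number unchanged. The same question applies to an amine or a carboxylic acid in place of the ethoxy.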